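A few compounds are considered here, and "the series" means these few. Any claim that something is new, unique, unknown or untested is made for them only; others in the source may bear on it.

Compound 1, `COc1cc(-c2nc3ccccc3s2)ccc1OCC(=O)NNC(=O)CN(C(C)=O)[C@@H](CS)C(=O)O`, was tested in a functional assay on HepG2 cells (Homo sapiens) for inhibition, read by MTT assay, with a stated time of 3 days (a lower number here means a stronger inhibitor, a higher number a weaker inhibitor), where compound 1 gives 3420 nM. Compound 3, `CCOC(=O)[C@H](CS)N(CC(=O)NNC(=O)COc1ccc(-c2nc3ccccc3s2)cc1OC)C(C)=O`, carries one change relative to compound 1, (ethyl in place of hydrogen on an oxygen next to a carbonyl group), and in this assay compound 3 gives 3010 nM; the step is a 1.1-fold lower number from compound 1 to compound 3 (0.06 log units; within the scatter).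

Compound 2, `COc1cc(-c2nc3ccccc3s2)ccc1OCC(=O)NNC(=O)CNC(=N)NCCC[C@H](N[N+](=O)[O-])C(=O)O`, shares the outer part of the molecule with compound 1, but the difference between the two cores is not broken down here. In this assay compound 2 gives 3490 nM, which sits within the scatter of both compound 1 and compound 3.

Compound 4, `CCOC(=O)[C@H](CCCNC(=N)NCC(=O)NNC(=O)COc1ccc(-c2nc3ccccc3s2)cc1OC)N[N+](=O)[O-]`, has not yet been measured. Relative to compound 2 it carries ethyl in place of hydrogen on an oxygen next to a carbonyl group, the same change that turns compound 1 into compound 3, at a place described in the same words. Going by the values given here, since that earlier step was a 1.1-fold lower number from compound 1 to compound 3 (0.06 log units; within the scatter), the expected step is a 1.1-fold lower number from compound 2 to compound 4 (0.05 log units; within the scatter), resting on the single measured pair alone. On that basis compound 4 is expected to give about 3100 nM in this assay, most likely between 1700 nM and 6000 nM.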

Compound 4, half-maximal inhibitory concentration: 3730 nM
The estimate for compound 4 lay 1.2-fold (0.08 log units) below the measured number; low and high end bracket the measured number.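

On the core of compound 2, going from carboxy to ethoxycarbonyl gives a 1.1-fold higher number from compound 2 to compound 4 (0.03 log units; within the scatter) in this assay. Set beside the earlier step, the change gives the same reading on both cores, as far as this assay can tell: the same change on two cores in this assay, a 1.1-fold lower number (0.06 log units; within the scatter) from compound 1 to compound 3 and a 1.1-fold higher number (0.03 log units; within the scatter) from compound 2 to compound 4, 1.2-fold (0.08 log units) apart, within the scatter of two such steps. This shows that putting ethyl in place of hydrogen on this oxygen left the number within the scatter on both cores, but it does not show that the change has any real effect, or that an effect would have a common size or direction, and two pairs say nothing about cores beyond these two.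

As far as these compounds go, what a methyl group, a longer chain or a benzyl group on this oxygen would do remains open, as does an amide in place of the ethoxycarbonyl group. Also open, from the compounds shown here alone, is whether the same change would stay this small in any assay other than this assay.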